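Swapping methyl for chloro in compound 3

The compounds below may be only part of what the source reports. "The series", "measured", "known", "first", "only" and "open" are said of these compounds alone.

Measured in a functional assay on MCF7 cells (Homo sapiens) for antiproliferative activity, read by MTT assay, with a stated time of 48 h; on this read-out higher numbers stand for weaker inhibition and lower numbers for stronger inhibition:
- Compound 1 `O=[N+]([O-])c1cccc(-c2nn(-c3ccccc3)cc2C(Nc2nc3ccccc3s2)c2c(O)ccc3ccccc23)c1` gives 43900 nM
- Compound 2 `Cc1ccc2nc(NC(c3cn(-c4ccccc4)nc3-c3cccc(Cl)c3)c3c(O)ccc4ccccc34)sc2c1` gives 49700 nM
- Compound 3 `Cc1cccc(-c2nn(-c3ccccc3)cc2C(Nc2nc3ccccc3s2)c2c(O)ccc3ccccc23)c1` gives 17300 nM

Compound 3 has the lowest number of the three, and its gaps to the other two lie beyond the usual scatter. The next compound is compound 4 `Oc1ccc2ccccc2c1C(Nc1nc2ccccc2s1)c1cn(-c2ccccc2)nc1-c1cccc(Cl)c1`, and the change is chloro in place of methyl on an aromatic carbon. In words, this is chloro in place of methyl on an aromatic carbon, or 3-methylphenyl to 3-chlorophenyl.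

For the measured compounds named here, only one measured step changes this same group: a 2.5-fold lower number from compound 1 to compound 3 (0.40 log units; beyond the scatter), with methyl in place of nitro. It is modest, and it involves no chloro. Compound 2 carries the 3-chlorophenyl group and gives 49700 nM, but its structure also differs from compound 3 elsewhere, so it offers only a loose guide. Together they suggest a small move towards a higher number in this assay, possibly not clearly beyond the scatter. The expected change is a 1.7-fold higher number from compound 3 to compound 4 (0.24 log units; within the scatter). For compound 4 the estimated value is 30000 nM, with an expected range from 14000 nM to 60000 nM.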

Compound 4, half-maximal inhibitory concentration: 20700 nM
Compound 4: the middle estimate sits 1.4-fold (0.16 log units) above what was measured; the range from low to high includes it.
By their numbers in this assay, from the lowest: compounds 3 and 4 (each within the scatter of the next); then compounds 1 and 2 (each within the scatter of the next).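

In this assay, going from 3-methylphenyl to 3-chlorophenyl gives a 1.2-fold higher number from compound 3 to compound 4 (0.08 log units; within the scatter) and so leaves the number in place, which means this position does not separate methyl from chloro. Nitro does stand apart from both, since its replacement by chloro gives a 2.1-fold lower number from compound 1 to compound 4 (0.33 log units; beyond the scatter) and adds a second case to the earlier 2.5-fold lower number from compound 1 to compound 3 (0.40 log units; beyond the scatter) step. With the 3-chlorophenyl group held constant, removing a methyl group elsewhere in the core gives a 2.4-fold lower number from compound 2 to compound 4 (0.38 log units; beyond the scatter) and shows that the number also responds to a change away from this phenyl ring.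

Nothing shown here explains why these numbers differ. Going by these compounds, it also remains open how an amine or a carboxylic acid at this position would read, and whether any group there could move the number further than methyl and chloro do.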